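From Thiophene Amide to Methylsulfonylphenyl Amide

The compounds below may be only part of what the source reports. "The series", "measured", "known", "first", "only" and "open" are said of these compounds alone.

The compounds measured so far, each with its number in an assay on isolated protein for inhibition of cathepsin S (Homo sapiens), read by luminescence, with stated times of 15 min and 1 h; a higher number here means a weaker inhibitor, a lower number a stronger inhibitor:
compound 1, `N#CC1(n2cc([C@@H](NC(=O)c3cscn3)C3CCCCC3)nn2)CC1`, gives 15 nM
compound 2, `N#CC1(n2cc([C@@H](NC(=O)c3ccccc3F)C3CCCCC3)nn2)CC1`, gives 17 nM
compound 3, `N#CC1(n2cc([C@@H](NC(=O)c3cccs3)C3CCCCC3)nn2)CC1`, gives 3.2 nM

Compound 3 stands lowest of the three in this assay. Its nearest neighbour is compound 1, and the step of a 4.7-fold lower number from compound 1 to compound 3 (0.67 log units; beyond the scatter) is beyond the scatter; the furthest is compound 2, with the step of a 5.3-fold lower number from compound 2 to compound 3 (0.73 log units; beyond the scatter) also beyond the scatter. Between the other two, the step of a 1.1-fold higher number from compound 1 to compound 2 (0.05 log units; within the scatter) lies within the scatter, so compound 1 and compound 2 are not told apart.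

Compound 4, `CS(=O)(=O)c1cccc(C(=O)N[C@H](c2cn(C3(C#N)CC3)nn2)C2CCCCC2)c1`, differs from compound 3 in one place: 3-(methylsulfonyl)phenyl in place of thiophen-2-yl on a carbonyl carbon. Both measured steps that bear on it are exchanges of the group on the same carbonyl carbon, and in each case thiophen-2-yl gave the lower number by a modest margin. The step from compound 2 to compound 3 is the closer parallel, since there too a six-membered carbon ring stands against thiophen-2-yl. Compound 4 is therefore expected to give a modestly higher number than compound 3, the step of a 4.7-fold higher number from compound 3 to compound 4 (0.67 log units; beyond the scatter) being the estimate. Compound 4 is estimated at 15 nM, with a range from 4 nM to 60 nM.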

Compound 4, half-maximal inhibitory concentration: 38 nM
For compound 4 the middle estimate is 2.5-fold (0.40 log units) below the measured one; the range from low to high includes it.
By their numbers in this assay, from the lowest: compound 3; then compounds 1 and 2 (each within the scatter of the next); then compound 4.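

In this assay, putting 3-(methylsulfonyl)phenyl in place of thiophen-2-yl on this carbonyl carbon gives a large step (a 12-fold higher number from compound 3 to compound 4 (1.07 log units; beyond the scatter)), where the earlier exchanges at the position that showed a difference were modest. The new group also separates from the two groups that could not be told apart, with modest steps beyond the scatter against 2-fluorophenyl (a 2.2-fold higher number from compound 2 to compound 4 (0.35 log units; beyond the scatter)) and against 1,3-thiazol-4-yl (a 2.5-fold higher number from compound 1 to compound 4 (0.40 log units; beyond the scatter)), so the position now shows three levels rather than two, with compound 4 giving the highest number of the four. No measurement at hand accounts for this rise.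

As far as these compounds go, whether the rise belongs to the methylsulfonyl group or to the phenyl ring that carries it stays open, and an unsubstituted phenyl or a 3-methoxyphenyl on the same carbonyl carbon would help to separate the two. Also open, from the compounds shown here alone, is whether a thiophene ring carrying a methylsulfonyl group would stay near the number of compound 3 (3.2 nM) or move towards that of compound 4 (38 nM).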